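The source may hold more compounds than are shown below. What is called first, only, known or untested is meant among the compounds shown, and "the series" means these compounds.

Compound 2 `COC1Cc2cc(-c3ccc(C(C)=O)cc3)sc2C2(CCN(Cc3ccccc3)CC2)O1` is measured in an assay on membranes from brain for displacement of a labelled ligand from Sigma non-opioid intracellular receptor 1 (Cavia porcellus), read by scintillation counting, with a stated time of 120 min (a lower number here means a stronger inhibitor, a higher number a weaker inhibitor), where compound 2 gives 59 nM, the higher of the two numbers recorded so far. Within the data shown here, its only neighbour is compound 1 `COC1Cc2cc(-c3ccc([N+](=O)[O-])cc3)sc2C2(CCN(Cc3ccccc3)CC2)O1`, and compound 1 gives 16 nM. Among the measured compounds shown here, the single measured step, a 3.7-fold higher number from compound 1 to compound 2 (0.57 log units; beyond the scatter), exchanged nitro for acetyl and moved the number by a modest amount. Compound 3 `COC1Cc2cc(-c3cccnc3)sc2C2(CCN(Cc3ccccc3)CC2)O1` has not yet been tested in this assay. Its change from compound 2 is pyridin-3-yl in place of 4-acetylphenyl on an aromatic carbon. For the measured compounds named here, no measured step matches this change directly: the step from compound 1 to compound 2 kept the six-membered aromatic ring of carbon only and altered just the group on it, whereas here the whole 4-acetylphenyl gives way to pyridin-3-yl. With only a modest precedent, the expected step is a 1.7-fold higher number from compound 2 to compound 3 (0.23 log units; within the scatter), a modest move toward a higher number with wide uncertainty. For compound 3 the estimate is 100 nM, with a range from 35 nM to 300 nM.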

Compound 3, inhibition constant: 2.5 nM
Compound 3: middle estimate off by 40-fold (1.60 log units), on the high side; the whole stated range lies above it.
By their numbers in this assay, from the lowest: compound 3; then compound 1; then compound 2.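

In this assay, the aromatic carbon next to the ring sulfur proves far more sensitive to exchanging the whole ring than the earlier swap of acetyl for nitro showed: pyridin-3-yl in place of 4-acetylphenyl gives a 24-fold lower number from compound 2 to compound 3 (1.37 log units; beyond the scatter), and in place of 4-nitrophenyl it gives a 6.4-fold lower number from compound 1 to compound 3 (0.81 log units; beyond the scatter). Both steps lie beyond the scatter, so compound 3 has the lowest number of the three, and a six-membered aromatic ring with a hetero atom and neither acetyl nor nitro is well accepted here. No measured evidence accounts for this gain.

As far as these compounds go, how a plain phenyl or a pyridin-4-yl would compare at this position stays open, so the entering ring nitrogen and the loss of acetyl or nitro cannot be told apart. Also open, from the compounds shown here alone, is whether an amine on the pyridin-3-yl ring would keep this low number.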